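A few compounds are considered here, and "the series" means these few. Any claim that something is new, unique, unknown or untested is made for them only; others in the source may bear on it.

In a functional assay on A549 cells (Homo sapiens) for antiproliferative activity, read by CCK-8 assay, with a stated time of 72 h (on this read-out higher numbers stand for weaker inhibition of growth and lower numbers for stronger inhibition of growth), compound 1 (`CCNC(=O)c1ccc2c(ccn2-c2ncc3c(n2)N(c2ccn(C)n2)C(CC)C(=O)N3C)c1`) gives 21700 nM and compound 2 (`CCC1C(=O)N(C)c2cnc(-n3ccc4cc(C(=O)NCC(C)C)ccc43)nc2N1c1ccn(C)n1`) gives 19200 nM so the two stand within the scatter of each other. Compound 3 (`CCC1C(=O)N(C)c2cnc(-n3ccc4cc(C(N)=O)ccc43)nc2N1c1ccn(C)n1`) carries hydrogen in place of isobutyl on an amide-type nitrogen. For the measured compounds named here, the one measured step bearing on this (a 1.1-fold lower number from compound 1 to compound 2 (0.05 log units; within the scatter)) changed only the chain on that nitrogen and stayed within the scatter. Going by the values given here, no measured step removes the chain altogether, so only a modest move toward a lower number is expected. The estimated step is a 1.9-fold lower number from compound 2 to compound 3 (0.28 log units; within the scatter) in this assay with wide uncertainty. Compound 3 is expected at 10000 nM within an estimated range of 2500 nM to 40000 nM in this read-out.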

Compound 3, concentration for 50% growth inhibition: 39500 nM
Compound 3: middle estimate off by 4.0-fold (0.60 log units), on the low side; measured number inside the range.
By their numbers in this assay, from the lowest: compounds 2, 1 and 3 (each within the scatter of the next, the first and the last beyond it).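

In this assay, for the compounds shown here, the only step at this position that passes the scatter is the full removal of the isobutyl chain from the amide-type nitrogen, which gives a 2.1-fold higher number from compound 2 to compound 3 (0.31 log units; beyond the scatter). Hydrogen in place of ethyl on the same nitrogen gives a 1.8-fold higher number from compound 1 to compound 3 (0.26 log units; within the scatter), so the bare carbamoyl compound separates from the isobutyl compound but not from the ethyl compound. Nothing measured offers a reason for this modest step.

Still open, going by these compounds, is whether a longer chain on this nitrogen would lower the number further. On these data alone, it is equally open whether a terminal amine or carboxylic acid on that chain would shift it.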